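A few compounds are considered here, and "the series" means these few. Any claim that something is new, unique, unknown or untested is made for them only; others in the source may bear on it.

Compound 1, with the structure `CCOc1cc(C)c(-c2cccc(CNc3ccc(OCC(=O)O)c(F)c3)c2)c(C)c1`, is the starting point here. It is measured in a functional assay on CHO cells for agonist activity at Free fatty acid receptor 1 (Homo sapiens), read by FLIPR and calcium flux (on this read-out lower numbers stand for an effect already at smaller amounts and higher numbers for an effect only at larger amounts of compound), where compound 1 gives 24.2 nM. A second compound, compound 2, with the structure `CCOc1cc(C)c(-c2cccc(COc3ccc(NCC(=O)O)c(F)c3)c2)c(C)c1`, rearranges the same parts of the molecule. For compound 2 the assay reports only a limit, > 1000 nM, and not a number. Among the two results shown, compound 1 therefore carries the only real number; the other result is the limit of > 1000 nM in this assay, at which 1 of the 2 values shown sits.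

Compound 3, with the structure `CCOc1cc(C)c(-c2cccc(CNc3ccc(OCC(=O)O)cc3)c2)c(C)c1`, is not yet measured. It differs from compound 1 in one spot: hydrogen in place of fluoro on an aromatic carbon. Among the measured compounds shown here, no pair of measured compounds differs in exactly this way, so no measured step tells how big such a swap is. A change of a single small atom like this is usually expected to move the result little, so in this assay the step is expected to stay within the usual scatter, in no clear direction. The expected 1.2-fold higher number from compound 1 to compound 3 (0.09 log units; within the scatter) is thus close to no change. Compound 3 is expected to give about 30 nM, within a range from 10 nM to 90 nM.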

Compound 3, half-maximal effective concentration: 197 nM
Estimate against measurement, compound 3: 6.6-fold (0.82 log units) below, outside the stated range (above it).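

Hydrogen in place of fluoro on the aromatic carbon ortho to a carboxymethoxy group gives an 8.1-fold higher number from compound 1 to compound 3 (0.91 log units; beyond the scatter) in this assay, so a change of one small atom at this position is enough to move the result clearly. Among the compounds shown here, this is the first measured size for any change at this position, which the earlier compounds did not vary. Of the two compounds, the one carrying fluoro, compound 1, acts at smaller amounts, but the results shown give no reason for the size of this step.

Whether this gain belongs to fluoro in particular stays open, as the compounds shown hold no other group on this carbon, such as chloro, methyl or methoxy, and no fluoro on another carbon of the same ring. Also open, going by these compounds, is whether hydrogen in place of fluoro would matter as much in the rearranged molecule, compound 2, whose result is only a limit and gives no number to compare against.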